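Sulfone-quinoxaline anilines: a methoxy on the second ring

A few compounds are considered here, and "the series" means these few. Any claim that something is new, unique, unknown or untested is made for them only; others in the source may bear on it.

Measured so far in a functional assay on A549 cells (Homo sapiens) for cytotoxicity, read by MTT assay, with a stated time of 72 h; on this read-out higher numbers stand for weaker inhibition and lower numbers for stronger inhibition:
compound 1 `O=S(=O)(c1ccccc1)c1nc2ccccc2nc1Nc1ccccc1`, 26300 nM
compound 2 `COc1cc(Nc2nc3ccccc3nc2S(=O)(=O)c2ccccc2)cc(OC)c1`, 70 nM
compound 3 `O=S(=O)(c1ccccc1)c1nc2ccccc2nc1Nc1ccc(Cl)cc1`, 30700 nM

Compound 2 stands lowest of the three numbers in this assay. Its nearest neighbour is compound 1, a step of a 380-fold lower number from compound 1 to compound 2 (2.57 log units; beyond the scatter) separating them, and the step of a 440-fold higher number from compound 2 to compound 3 (2.64 log units; beyond the scatter) is larger still. For the measured compounds named here, both of those steps change the group on the nitrogen; the one step that leaves that group alone, a 1.2-fold higher number from compound 1 to compound 3 (0.07 log units; within the scatter), stays within the scatter.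

Compound 4 `COc1ccc(S(=O)(=O)c2nc3ccccc3nc2Nc2cc(OC)cc(OC)c2)cc1` keeps the 3,5-dimethoxyphenyl of compound 2 and differs from it only in methoxy in place of hydrogen on an aromatic carbon. No measured step touches this ring, so nothing shown bears directly on the change. Going by the values given here, the only substituent step on an aromatic carbon without change of the nitrogen-bound group, from compound 1 to compound 3, was small. The expected step is therefore no change at the digits printed from compound 2 to compound 4 (within the scatter), nothing beyond the scatter. Compound 4 is expected to give 70 nM, with a range from 20 nM to 250 nM.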

Compound 4, half-maximal inhibitory concentration: 12700 nM
Compound 4: the middle estimate sits 180-fold (2.26 log units) below what was measured; measured number above the stated range.
By their numbers in this assay, from the lowest: compound 2; then compound 4; then compounds 1 and 3 (each within the scatter of the next).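

In this assay, the change from phenyl to 4-methoxyphenyl is not silent: methoxy in place of hydrogen gives a 180-fold higher number from compound 2 to compound 4 (2.26 log units; beyond the scatter). Until now, only changes to the group on the nitrogen had moved the number beyond the scatter, while the one aromatic-carbon substitution that left that group alone, a 1.2-fold higher number from compound 1 to compound 3 (0.07 log units; within the scatter), stayed within it; a step beyond the scatter can therefore also arise on the second ring. No evidence at hand explains this step.

Whether the step belongs to methoxy itself or to any group at this place remains open, since a fluorine, a hydroxyl or an amine on the same carbon is not among the compounds shown. Also open, on these data alone, is whether the same change would carry over with phenyl or 4-chlorophenyl on the nitrogen, as in compound 1 and compound 3, where the number already stands high.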